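The source may report more compounds than this note shows. Statements on the series, on what has been measured and on what is new or still open speak of the compounds shown alone.

Measured so far in an assay on HepG2 cells for agonist activity at nuclear receptor subfamily 1 group I member 3 (Homo sapiens), read by a luciferase reporter, with a stated time of 23 h; on this read-out lower numbers stand for an effect already at smaller amounts and higher numbers for an effect only at larger amounts of compound:
compound 1 `Clc1cccc(-c2nc3sccn3c2/C=N/OCc2ccc(Cl)c(Cl)c2)c1` gives 1100 nM
compound 2 `CC(C)(C)c1ccc(-c2nc3sccn3c2/C=N/OCc2ccc(Cl)c(Cl)c2)cc1` gives 2400 nM

Going by the values given here, compound 2 stands at the higher of the two numbers in this assay; its only neighbour is compound 1, and the single measured step, a 2.2-fold higher number from compound 1 to compound 2 (0.34 log units; beyond the scatter), runs from the lower number to the higher one. Compound 3 `Fc1ccc(-c2nc3sccn3c2/C=N/OCc2ccc(Cl)c(Cl)c2)cc1` has not yet been measured. It differs from compound 2 by fluoro in place of tert-butyl on an aromatic carbon. Among the compounds with values here, no measured step covers this exact exchange. Within the data shown here, the one step that bears on it, a 2.2-fold higher number from compound 1 to compound 2 (0.34 log units; beyond the scatter), shows that the group on the phenyl ring shifts the number by a modest amount, with the 3-chlorophenyl of compound 1 at the lower number and the 4-(tert-butyl)phenyl of compound 2 at the higher one. In compound 3 a halogen again takes the place of the tert-butyl group, so a modest move back towards the number of compound 1 is expected, tempered by the fact that 3-chlorophenyl and 4-fluorophenyl are not the same group. Compound 3 is therefore expected to give 1500 nM in this assay, within a range from 600 nM to 4000 nM. This corresponds to an expected step of a 1.6-fold lower number from compound 2 to compound 3 (0.20 log units; within the scatter).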

Compound 3, half-maximal effective concentration: 670 nM
Compound 3: middle estimate off by 2.2-fold (0.35 log units), on the high side; measured number inside the range.
By their numbers in this assay, from the lowest: compounds 3 and 1 (each within the scatter of the next); then compound 2.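

Changing only the group at this place on the phenyl ring, in this assay, tert-butyl to fluoro gives a clear shift (a 3.6-fold lower number from compound 2 to compound 3 (0.55 log units; beyond the scatter)), a reading the earlier pair could not give, since 3-chlorophenyl and 4-(tert-butyl)phenyl differ in where the group sits as well as in what it is. The exchange of 3-chlorophenyl for 4-fluorophenyl, by contrast, gives no separable difference (a 1.6-fold lower number from compound 1 to compound 3 (0.22 log units; within the scatter)), so the two halogen-bearing compounds cannot be ordered, and compound 2 alone stands apart, with its steps to both others beyond the scatter (a 2.2-fold higher number from compound 1 to compound 2 (0.34 log units; beyond the scatter)). Nothing given here accounts for these differences.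

The compounds shown leave open whether a methoxy group, an amine or a carboxylic acid at this place would fall with fluoro or with tert-butyl, and whether a chain shorter than tert-butyl, such as methyl, would already raise the number. They also leave open how 4-chlorophenyl or 3-fluorophenyl would read, which would separate the choice of halogen from where it sits on the ring.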